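A few compounds are considered here, and "the series" means these few. Any claim that something is new, unique, unknown or untested is made for them only; others in the source may bear on it.

Measured compounds:
compound 1, `C[C@H]1C[C@@H](O)[C@@]23C1=C[C@@]1(C)CC[C@](C)(C[C@H](O)[C@H](O)[C@@](C)(O)CO)[C@H]1[C@@H]2CC[C@@H]3C` — 18000 nM
compound 2, `C[C@H]1CC[C@@]23C1=C[C@@]1(C)CC[C@](C)(C[C@H](O)[C@H](O)[C@@](C)(O)CO)[C@H]1[C@@H]2C[C@@H](O)[C@@H]3C` — 18000 nM

In a functional assay on cells (Panel NCI-60 (60 carcinoma cell lines), Homo sapiens) for inhibition (on this read-out lower numbers stand for stronger inhibition and higher numbers for weaker inhibition), compound 1 gives 18000 nM, and compound 2 gives 18000 nM; the two stand level within the scatter, so compound 1 is neither stronger nor weaker than its nearest neighbour. Compound 3, `C[C@H]1C[C@@H](O)[C@@]23C1=C[C@@]1(C)CC[C@](C)(C[C@H](O)[C@H](O)C(C)(C)O)[C@H]1[C@@H]2CC[C@@H]3C`, has not been measured. It differs from compound 1 by hydrogen in place of hydroxy on a saturated chain carbon, two bonds along the chain from an oxygen on a saturated carbon. Within the data shown here, no measured pair shows the effect of removing that hydroxy, so the expected step of a 1.1-fold higher number from compound 1 to compound 3 (0.05 log units; within the scatter) is small, with no clear direction beyond the scatter. Compound 3 is therefore estimated at 20000 nM, within 7000 nM to 55000 nM.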

Compound 3, half-maximal inhibitory concentration: 18000 nM
The estimate for compound 3 lay 1.1-fold (0.05 log units) above the measured number, within the range that was stated.
By their numbers in this assay, from the lowest: compounds 1, 2 and 3 (each within the scatter of the next).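

In this assay, among these compounds, putting hydrogen in place of the hydroxy on this saturated chain carbon gives no change at the digits printed from compound 1 to compound 3 (within the scatter) and is the first step read at this position. Here, 1-hydroxy-1-(hydroxymethyl)ethyl and 1-hydroxy-1-methylethyl cannot be told apart by their numbers. Nothing at hand accounts for this result. Still open, from the compounds shown here alone, is whether an amine, a carboxylic acid or a longer chain on this carbon would shift the number, and whether the same change would read alike on compound 2.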